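Side-chain variation on the oxime oxygen in one series

The source may report more compounds than this note shows. Statements on the series, on what has been measured and on what is new or still open speak of the compounds shown alone.

Measured so far:
compound 1 `CCOC(=O)CCO/N=C(/c1ccc(OC)c(OC)c1OC)c1cccc2ccccc12`: 19600 nM
compound 2 `CCOC(=O)CO/N=C(/c1ccc(OC)c(OC)c1OC)c1cccc2ccccc12`: 6720 nM
compound 3 `COc1ccc(/C(=N/OCC(=O)O)c2cccc3ccccc23)c(OC)c1OC`: 17200 nM

In a functional assay on A549 cells (Homo sapiens) for inhibition, read by sulforhodamine B assay, with a stated time of 48 h (a higher number here means a weaker inhibitor, a lower number a stronger inhibitor), compound 1 gives 19600 nM, compound 2 gives 6720 nM and compound 3 gives 17200 nM. Compound 3 and compound 1 cannot be told apart, as a 1.1-fold lower number from compound 1 to compound 3 (0.06 log units; within the scatter) shows. Against compound 2 the picture differs: a 2.6-fold higher number from compound 2 to compound 3 (0.41 log units; beyond the scatter), a step that puts a hydrogen-bond donor on the chain. Shortening the chain while keeping the ethyl read a 2.9-fold lower number from compound 1 to compound 2 (0.46 log units; beyond the scatter).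

Compound 4 `COc1ccc(/C(=N/OC(C)=O)c2cccc3ccccc23)c(OC)c1OC` differs from compound 3 by acetyl in place of carboxymethyl on an oxygen. Both measured steps bear on it: the change removes the hydrogen-bond donor that compound 3 carries, which in a 2.6-fold higher number from compound 2 to compound 3 (0.41 log units; beyond the scatter) went with a higher number, and it shortens the chain, which in a 2.9-fold lower number from compound 1 to compound 2 (0.46 log units; beyond the scatter) went with a lower number. A modest lower number in this assay is therefore expected for compound 4, landing near compound 2 rather than far below it, estimated as a 2.2-fold lower number from compound 3 to compound 4 (0.33 log units; beyond the scatter). Compound 4 is accordingly estimated at 8000 nM, with a range from 3000 nM to 24000 nM.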

Compound 4, half-maximal inhibitory concentration: 17200 nM
Compound 4: middle estimate off by 2.2-fold (0.33 log units), on the low side; the range from low to high includes it.
By their numbers in this assay, from the lowest: compound 2; then compounds 3, 4 and 1 (each within the scatter of the next).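

In this assay, the loss of the hydrogen-bond donor on an oxygen whose other neighbours are double-bonded nitrogen brings no separation (no change at the digits printed from compound 3 to compound 4 (within the scatter)), so the donor count alone does not track the number across these compounds. Acetyl also reads alike with 2-(ethoxycarbonyl)ethyl (a 1.1-fold lower number from compound 1 to compound 4 (0.06 log units; within the scatter)) but not with (ethoxycarbonyl)methyl (a 2.6-fold higher number from compound 2 to compound 4 (0.41 log units; beyond the scatter)), which leaves compound 2 alone at the low end of the four and shows that a small side chain by itself does not give the lower number. Nothing available accounts for why compound 2 stands apart from the other three.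

On these data alone, whether an amide or an amine on the same side chain would separate from these values remains open. Also open, as far as these compounds go, is whether the lower number of compound 2 persists with a methyl ester or a tert-butyl ester in place of the ethyl ester.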